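The source may report more compounds than this note shows. Statements on the series, on what has been measured and on what is new or still open speak of the compounds shown alone.

Among the compounds with values here, in a functional assay on OVCAR-4 cells (Homo sapiens) for inhibition, read by sulforhodamine B assay, with a stated time of 48 h (on this read-out lower numbers stand for stronger inhibition of growth and higher numbers for weaker inhibition of growth), compound 1 `Cc1nnc(-c2nn(-c3ccccc3)c(-c3ccccc3)c2C#N)c2cn(-c3ccccc3)nc12` gives 56400 nM and compound 2 `N#Cc1c(-c2nnc(-c3ccccc3)c3nn(-c4ccccc4)cc23)nn(-c2ccccc2)c1-c1ccccc1` gives 63000 nM, so compound 2 stands level with its only measured neighbour. Compound 3 `Cc1ccc(-n2cc3c(-c4nn(-c5ccccc5)c(-c5ccccc5)c4C#N)nnc(-c4ccccc4)c3n2)cc1` differs from compound 2 by methyl in place of hydrogen on an aromatic carbon. Within the data shown here, only one measured step bears on this, phenyl in place of methyl on an aromatic carbon, at another place in the molecule, and it stays within the scatter: a 1.1-fold higher number from compound 1 to compound 2 (0.05 log units; within the scatter). No change beyond the scatter is therefore expected, and the estimated step is a 1.1-fold lower number from compound 2 to compound 3 (0.02 log units; within the scatter). For compound 3 the expected value is 60000 nM, with an estimated range of 30000 nM to 100000 nM.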

Compound 3, concentration for 50% growth inhibition: 5490 nM
For compound 3 the middle estimate is 11-fold (1.04 log units) above the measured one; measured number below the stated range.
By their numbers in this assay, from the lowest: compound 3; then compounds 1 and 2 (each within the scatter of the next).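

Adding one methyl, which turns phenyl into 4-methylphenyl, gives an 11-fold lower number from compound 2 to compound 3 (1.06 log units; beyond the scatter) in this assay. This aromatic carbon, para to a large group, is therefore sensitive to even a one-carbon addition, whereas the earlier swap of methyl for phenyl, at another place in the molecule, stayed within the scatter. Nothing available explains this step.

On these data alone, whether methyl is special or other groups at this carbon would do the same remains open. An ethyl chain, a methoxy group, a chlorine atom or an amine there could help settle that.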